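This account rests on a few compounds, and the source may have more. Where it says the series, first, only, none or still open, it means among the compounds named here.

Working notes on the series. Among the compounds with values here, in a functional assay on HeLa cells (Homo sapiens) for antiproliferative activity, read by resazurin assay (on this read-out lower numbers stand for stronger inhibition and higher numbers for weaker inhibition), compound 1 (`CCSC(=S)SCC(=O)c1ccc(NS(C)(=O)=O)cc1`) gives 39800 nM, the higher of the two numbers available so far. Compound 2 (`CCSC(=S)SC(C)C(=O)c1ccccc1`) gives 5010 nM, and the gap between the two lies beyond the usual scatter. These two compounds differ in more than one place, so the gap cannot be assigned to any single group.

The next compound is compound 3 (`CCSC(=S)SCC(=O)c1ccc(N(CC)CC)cc1`), which keeps the rest of compound 1 and has diethylamino in place of methanesulfonamido on an aromatic carbon. Within the data shown here, no step between measured compounds isolates this change, so any expectation rests on thin evidence. Compound 2, at 5010 nM, carries neither group and still reads lower, which gives weak support for a move away from the value of compound 1. Among the measured compounds shown here, a moderate step towards lower numbers is therefore expected in this assay, probably beyond the scatter, though no step at all cannot be excluded. The expected change is a 3.3-fold lower number from compound 1 to compound 3 (0.52 log units; beyond the scatter). For compound 3 the estimated value is 12000 nM, with an expected range of 4000 nM to 36000 nM.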

Compound 3, half-maximal inhibitory concentration: 3160 nM
Compound 3: middle estimate off by 3.8-fold (0.58 log units), on the high side, and the stated range ends above it.
By their numbers in this assay, from the lowest: compounds 3 and 2 (each within the scatter of the next); then compound 1.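

In this assay, within the data shown here, diethylamino in place of methanesulfonamido on an aromatic carbon, para to a group of 9 heavy atoms, gives a 13-fold lower number from compound 1 to compound 3 (1.10 log units; beyond the scatter), the first step that can be assigned to a single place. This place therefore tolerates no free exchange of groups: the read-out shifts strongly when the substituent changes, even though both groups have 5 heavy atoms and neither has a net charge. The two groups differ in their atoms and in their counts of hydrogen-bond donors and acceptors, but no measurement available here accounts for the step, which stands as an observation only.

As far as these compounds go, with a single step at this place, it remains open whether the size of the step follows the loss of the hydrogen-bond donor, the loss of the sulfonyl group or the arrival of the two ethyl chains; a primary amine, dimethylamino or methoxy at the same place would help to separate these. From the compounds shown here alone, it also remains open whether diethylamino would give a similar step on the core of compound 2.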